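Methoxy in place of chloro: what compound 4 might show

This account rests on a few compounds, and the source may have more. Where it says the series, first, only, none or still open, it means among the compounds named here.

Three hydrazones built on a shared core have so far been examined in an ADME assay on J774 cells (Mus musculus) for cytotoxicity, read by MTT assay, with a stated time of 48 h, tested at 50 ug/mL; a lower number here means a stronger effect, a higher number a weaker effect of the compound at the concentration tested. Compound 1 `O=C(N/N=C/c1ccccc1Cl)c1cnccn1` gives 70% in this assay. Compound 2 `O=C(N/N=C/c1ccc(F)cc1)c1cnccn1` gives 78%, and compound 3 `O=C(N/N=C/c1cccc(Br)c1)c1cnccn1` gives 100%. Compound 1 stands lowest of the three numbers, but its nearest neighbour, compound 2, lies within the usual scatter of it, so no order between those two can be claimed; only compound 3 sits beyond the scatter, with a clearly weaker effect than compound 1.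

Compound 4 `COc1ccccc1/C=N/NC(=O)c1cnccn1` has not yet been measured. It differs from compound 1 in a single place: methoxy in place of chloro on an aromatic carbon. For the measured compounds named here, no pair of measured compounds differing in one place is available, so nothing is known about how a change of this kind has moved the numbers here. The three measured compounds span a modest range, and the expected step is therefore small: the estimated change from compound 1 to compound 4 is a number 8 percentage points higher from compound 1 to compound 4 (within the scatter), pointing to a slightly weaker effect but not beyond the scatter. Compound 4 is accordingly expected to give 78% in this assay, with an estimated range from 60% to 95%.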

Compound 4, a percentage reported as activity, at one concentration (the size of the read-out at that concentration, not a potency): 97%
Compound 4: the middle estimate sits 19 percentage points below what was measured; measured number above the stated range.
By their numbers in this assay, from the lowest: compounds 1 and 2 (each within the scatter of the next); then compounds 4 and 3 (each within the scatter of the next).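

For the compounds shown here, the change of chloro to methoxy on an aromatic carbon, ortho to a large group, gives the first single-place step that can be read in this assay: it is a number 27 percentage points higher from compound 1 to compound 4 (beyond the scatter) and points to a weaker effect at the tested concentration. The earlier compounds shown here could not show this, as none of them differed from another in one place only, whereas this pair shows that the group at this position can move the number beyond the scatter. Nothing in the data shown speaks to what lies behind the step.

Whether the step reflects the arrival of methoxy or the departure of chloro stays open, since the compounds shown offer only these two groups at this position on the shared core. An amine, a hydroxyl group or a longer ether such as ethoxy in the same place would show whether the number stays near that of compound 4 or moves back towards that of compound 1.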